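Swapping the Aromatic Ring for a Lactam Chain

A few compounds are considered here, and "the series" means these few. Any claim that something is new, unique, unknown or untested is made for them only; others in the source may bear on it.

Three compounds share one core and differ only in the group on a saturated chain carbon bound to an aromatic carbon and a saturated chain carbon. In an assay on CHO cells for displacement of a labelled ligand from prostaglandin E2 receptor EP3 subtype (Homo sapiens), read by radioligand binding (on this read-out higher numbers stand for weaker inhibition and lower numbers for stronger inhibition), compound 1 `CC(C)C(c1ncco1)c1ccc(-c2ccc3cccc(F)c3c2)[nH]c1=O` gives 24 nM. Compound 2 `CC(C)C(c1cnc(N)s1)c1ccc(-c2ccc3cccc(F)c3c2)[nH]c1=O` gives 16 nM in this assay, and compound 3 `CC(C)C(c1ncc[nH]1)c1ccc(-c2ccc3cccc(F)c3c2)[nH]c1=O` gives 7.3 nM, the lowest of the three numbers; the step of a 3.3-fold lower number from compound 1 to compound 3 (0.52 log units; beyond the scatter) and the step of a 2.2-fold lower number from compound 2 to compound 3 (0.34 log units; beyond the scatter) both lie beyond the scatter, while a 1.5-fold lower number from compound 1 to compound 2 (0.18 log units; within the scatter) does not. Compound 4 `CC(C)C(/C=C1/CCNC1=O)c1ccc(-c2ccc3cccc(F)c3c2)[nH]c1=O` is not yet measured; it differs from compound 3 in that (a group of 7 heavy atoms (5 carbon, 1 nitrogen, 1 oxygen; one five-membered non-aromatic ring with 1 hetero atom) in place of a group of 5 heavy atoms (3 carbon, 2 nitrogen; one five-membered aromatic ring with 2 hetero atoms), on a saturated chain carbon bound to an aromatic carbon and a saturated chain carbon). The three measured steps all exchanged one five-membered aromatic ring for another at this place, and none of them went beyond a modest size. Among the compounds with values here, no measured step exchanges an aromatic ring for a non-aromatic one, so the change to compound 4 reaches outside what the data cover. A small to moderate rise in the number is expected, since compound 3 already holds the lowest value 7.3 nM. The expected step is a 2.1-fold higher number from compound 3 to compound 4 (0.31 log units; beyond the scatter). Compound 4 is therefore estimated at 15 nM, with a range from 5 nM to 50 nM.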

Compound 4, inhibition constant: 5.3 nM
Compound 4: the middle estimate sits 2.8-fold (0.45 log units) above what was measured; the measured number falls inside the stated range.
By their numbers in this assay, from the lowest: compounds 4 and 3 (each within the scatter of the next); then compounds 2 and 1 (each within the scatter of the next).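

In this assay, the first non-aromatic ring at this place reads level with the 1H-imidazol-2-yl group of the earlier series (a 1.4-fold lower number from compound 3 to compound 4 (0.14 log units; within the scatter)). The same group also stands clear of the other two aromatic rings (a 3.0-fold lower number from compound 2 to compound 4 (0.48 log units; beyond the scatter); a 4.5-fold lower number from compound 1 to compound 4 (0.66 log units; beyond the scatter)), so among these four compounds an aromatic ring on this saturated chain carbon is not needed for a low number. Nothing measured here explains why the numbers fall this way.

The compounds shown leave open how a group with no ring at all, such as a carboxylic acid or an open-chain amide, would read at this place. Also open, from the compounds shown here alone, is whether a fully saturated ring, such as pyrrolidine, would hold the number as well.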